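Benzylsulfanyl variation on the shared core

A few compounds are considered here, and "the series" means these few. Any claim that something is new, unique, unknown or untested is made for them only; others in the source may bear on it.

Compound 1 `Cc1ccc(CSc2cc(Cl)c(C)cc2S(=O)(=O)/N=C(\N)n2nc(C)cc2-c2ccccc2)cc1` gives 89000 nM in a functional assay on MCF7 cells (Homo sapiens) for cytotoxicity, read by MTT assay, with a stated time of 72 h (a lower number here means a stronger inhibitor, a higher number a weaker inhibitor), the highest number among the measured compounds; compound 3 `Cc1cc(S(=O)(=O)/N=C(\N)n2nccc2-c2ccccc2)c(SCc2ccc(Cl)cc2)cc1Cl` sits at 75000 nM, within the scatter of compound 1, while compound 2 `Cc1cc(S(=O)(=O)/N=C(\N)n2nccc2-c2ccccc2)c(SCc2ccccc2C)cc1Cl` gives 23000 nM. Among the measured compounds shown here, the only measured step at this position is a 3.3-fold higher number from compound 2 to compound 3 (0.51 log units; beyond the scatter). Compound 4 `Cc1cc(-c2ccccc2)n(/C(N)=N/S(=O)(=O)c2cc(C)c(Cl)cc2SCc2ccccc2Cl)n1` differs from compound 1 by 2-chlorophenyl in place of 4-methylphenyl on a saturated chain carbon bound to a sulfur. This is not the same exchange as the measured step, which changes both the group and its place on the ring, so the direction is read only loosely: compound 2, with 2-methylphenyl on this carbon, gives the lowest number, so a modest lowering is expected for compound 4, a 1.8-fold lower number from compound 1 to compound 4 (0.25 log units; within the scatter). Compound 4 is therefore estimated at 50000 nM, within 20000 nM to 120000 nM.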

Compound 4, half-maximal inhibitory concentration: 135000 nM
Estimate against measurement, compound 4: 2.7-fold (0.43 log units) below; measured number outside the range, above it.
By their numbers in this assay, from the lowest: compound 2; then compounds 3, 1 and 4 (each within the scatter of the next).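

In this assay, placing 2-chlorophenyl in place of 4-methylphenyl on a saturated chain carbon bound to a sulfur gives a 1.5-fold higher number from compound 1 to compound 4 (0.18 log units; within the scatter), so this change does not separate the two compounds on the core of compound 1. The earlier step, a 3.3-fold higher number from compound 2 to compound 3 (0.51 log units; beyond the scatter), stands on a different core and cannot be set against this one. No measurement available here offers an explanation for this result.

Going by these compounds, whether 2-methylphenyl on the core of compound 1 would match the number of compound 2 stays open. Also open, on these data alone, are a carboxylic acid or an amine on this phenyl ring and a longer chain between the sulfur and the ring.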